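Methoxy in Place of Chloro in a Cytotoxicity Series

The source may hold more compounds than are shown below. What is called first, only, known or untested is meant among the compounds shown, and "the series" means these compounds.

Compound 1 `Fc1ccc(-c2cn3nc(Cc4ccc(Cl)cc4)sc3n2)cc1`: in a functional assay on L1210 cells (Mus musculus) for cytotoxicity, with a stated time of 48 h (on this read-out lower numbers stand for stronger inhibition and higher numbers for weaker inhibition), compound 1 gives > 250000 nM, which is a limit of the assay.
Compound 2 `Clc1ccc(-c2cn3nc(Cl)sc3n2)cc1`: in this assay compound 2 gives > 250000 nM, again a limit.
Compound 3 `Clc1ccc(Cc2nn3cc(-c4ccc(Br)cc4)nc3s2)cc1`: in this assay compound 3 gives > 250000 nM, also a limit.

Compound 2 therefore has no number of its own, only a limit, and the other two values shown are limits as well. Within the data shown here, the one measured step, a step that the two limits leave unreadable from compound 1 to compound 3, cannot be read because both ends sit at the limit of > 250000 nM in this assay, at which 3 of the 3 values shown sit. Compound 4 `COc1ccc(-c2cn3nc(Cl)sc3n2)cc1` differs from compound 2 by methoxy in place of chloro on an aromatic carbon. Among the measured compounds shown here, no measured step touches this kind of change, so nothing in the data argues for a readable gain, and compound 4 is expected to remain at the limit, with a number no higher from compound 2 to compound 4 (the limit leaves the size open) as the estimated step. For compound 4 the estimate in this assay is 250000 nM, within 100000 nM to 1000000 nM.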

Compound 4, half-maximal inhibitory concentration: 38000 nM
Compound 4: the middle estimate sits 6.6-fold (0.82 log units) above what was measured; measured number below the stated range.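

In this assay, methoxy in place of chloro on the six-membered aromatic ring gives an at least 6.5-fold lower number from compound 2 to compound 4 (0.81 log units; beyond the scatter). Among these compounds, the earlier step could not be read, so this is the first sign that a change at this place can move the read-out. Compound 4 is also the only compound shown with a number of its own, while the others stop at a limit: the limit of > 250000 nM in this assay, at which 3 of the 4 values shown sit.

On these data alone, it remains open whether methoxy would have the same effect in compound 1 or compound 3, which carry a different group elsewhere on the core. As far as these compounds go, how an amine or an ethoxy group would read at this place is also open.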